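A ring exchange on the core of compound 1

The source may hold more compounds than are shown below. What is called first, only, known or untested is meant among the compounds shown, and "the series" means these compounds.

Compound 1 `Cc1cncc(-c2ccc3[nH]c(=O)nc(-c4ccccc4)c3c2)c1` was examined in an ADME assay on L6 cells (Rattus norvegicus) for cytotoxicity, read by fluorescence and resazurin assay, with a stated time of 72 h; a lower number here means that less compound is needed, a higher number that more compound is needed for the effect. In this assay compound 1 gives > 50000 nM, which is a limit of the assay rather than a measured number. Compound 1 therefore stands at the limit of > 50000 nM in this assay, at which 1 of the 2 values shown sits. Compound 2 `CN(C)c1ccc(-c2ccc3[nH]c(=O)nc(-c4ccccc4)c3c2)cn1` gives 50000 nM in this assay. Compound 3 `CN1CCN(c2ccc3[nH]c(=O)nc(-c4ccccc4)c3c2)CC1` has not yet been measured; it differs from compound 1 in one place: 4-methylpiperazin-1-yl in place of 5-methylpyridin-3-yl on an aromatic carbon. For the measured compounds named here, no measured pair shows the effect of this change, so the step is expected to be a number no higher from compound 1 to compound 3 (the limit leaves the size open), within the scatter. Compound 3 is therefore expected to give 50000 nM, with a range from 20000 nM to 100000 nM.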

Compound 3, half-maximal effective concentration: > 50000 nM
Compound 3 ended at the assay's limit; the forecaster's own chance of this, stated with the estimate: 60%; the middle value sits exactly at the limit.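

No step can be read between compound 1 and compound 3, because each stands at a limit of the assay rather than a measured number: the limit of > 50000 nM in this assay, at which 2 of the 3 values shown sit.

The compounds shown leave open how far past that limit either compound lies, and so whether this ring exchange changes the read-out at all.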